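Chloro in Place of Fluoro in a Small Series

The source may hold more compounds than are shown below. What is called first, only, known or untested is meant among the compounds shown, and "the series" means these compounds.

In a functional assay on HCT-116 cells (Homo sapiens) for antiproliferative activity, read by MTT assay, with a stated time of 72 h (a lower number here means a stronger inhibitor, a higher number a weaker inhibitor), compound 1 (`COc1ccc(/C=C2/CN(C)/C(=N/c3ccc(OC)cc3)S2)cc1`) gives 15900 nM, and compound 2 (`COc1ccc(/C=C2/CN(C)/C(=N/c3ccc(C(F)(F)F)cc3)S2)cc1`) gives 34300 nM. Compound 3 (`COc1ccc(/C=C2/CN(C)/C(=N/c3ccc(F)cc3)S2)cc1`) gives 10000 nM, within the scatter of compound 1 and clearly under compound 2. Compound 4 (`COc1ccc(/C=C2/CN(C)/C(=N/c3ccc(Cl)cc3)S2)cc1`) has chloro in place of fluoro on an aromatic carbon, para to a large group: chloro in place of fluoro on an aromatic carbon. Three measured exchanges at that carbon bear on this. They gave a 1.6-fold lower number from compound 1 to compound 3 (0.20 log units; within the scatter), a 2.2-fold higher number from compound 1 to compound 2 (0.33 log units; beyond the scatter) and a 3.4-fold lower number from compound 2 to compound 3 (0.54 log units; beyond the scatter), so even the largest stayed modest. The expected change is a 1.3-fold higher number from compound 3 to compound 4 (0.11 log units; within the scatter), which would not go beyond the scatter. For compound 4 the estimated value is 13000 nM, with an expected range of 6000 nM to 28000 nM.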

Compound 4, half-maximal inhibitory concentration: 9800 nM
Compound 4: middle estimate off by 1.3-fold (0.12 log units), on the high side; the measured number falls inside the stated range.
By their numbers in this assay, from the lowest: compounds 4, 3 and 1 (each within the scatter of the next); then compound 2.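

In this assay chloro at this carbon cannot be told apart from fluoro (a 1.0-fold lower number from compound 3 to compound 4 (0.01 log units; within the scatter)) or from methoxy (a 1.6-fold lower number from compound 1 to compound 4 (0.21 log units; within the scatter)), so three of the four groups now sit within the scatter of one another. Only trifluoromethyl stands apart, and the gap to chloro (a 3.5-fold lower number from compound 2 to compound 4 (0.54 log units; beyond the scatter)) is modest and matches the one to fluoro (a 3.4-fold lower number from compound 2 to compound 3 (0.54 log units; beyond the scatter)). Nothing given here accounts for this reading. Going by these compounds, whether an amine, a carboxylic acid or a longer chain at this carbon would leave the number as flat remains open.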